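Aryl swap on the amide carbonyl: compound 2 to compound 4

A few compounds are considered here, and "the series" means these few. Any claim that something is new, unique, unknown or untested is made for them only; others in the source may bear on it.

In a functional assay on A549 cells (Homo sapiens) for antiproliferative activity, read by CCK-8 assay, with a stated time of 72 h (a lower number here means a stronger inhibitor, a higher number a weaker inhibitor), compound 1 (`Cc1nc(C)c(/C=C/C(=O)c2ccc(NC(=O)c3ccccc3F)cc2)nc1C`) gives 7390 nM while compound 2 (`Cc1nc(C)c(/C=C/C(=O)c2ccc(NC(=O)c3ccc(F)cc3)cc2)nc1C`) gives 4480 nM and compound 3 (`COc1ccc(C(=O)Nc2ccc(C(=O)/C=C/c3nc(C)c(C)nc3C)cc2)cc1`) gives 4150 nM on the same read-out. Compound 2 therefore stands inside a group of three numbers that the scatter does not separate.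

Compound 4 (`COc1cc(OC)cc(C(=O)Nc2ccc(C(=O)/C=C/c3nc(C)c(C)nc3C)cc2)c1`) has 3,5-dimethoxyphenyl in place of 4-fluorophenyl on a carbonyl carbon. Among the measured compounds shown here, no measured compound carries 3,5-dimethoxyphenyl, so the comparison is indirect.

For the measured compounds named here, three measured steps bear on the change. Methoxy in place of fluoro on an aromatic carbon is a 1.1-fold lower number from compound 2 to compound 3 (0.03 log units; within the scatter) and 4-methoxyphenyl in place of 2-fluorophenyl on a carbonyl carbon is a 1.8-fold lower number from compound 1 to compound 3 (0.25 log units; within the scatter) while 4-fluorophenyl in place of 2-fluorophenyl on a carbonyl carbon is a 1.6-fold lower number from compound 1 to compound 2 (0.22 log units; within the scatter) in the same series. All three stay within the scatter, and none of them gives a direction to carry forward.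

No step beyond the scatter is expected in this assay, and the estimated step is a 1.1-fold lower number from compound 2 to compound 4 (0.05 log units; within the scatter) on this basis. Going by the values given here, the range is kept wide because the new group has no measured precedent. The expected value for compound 4 is 4000 nM with an estimated range from 1700 nM to 9500 nM in this read-out.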

Compound 4, half-maximal inhibitory concentration: 10200 nM
Compound 4: the middle estimate sits 2.6-fold (0.41 log units) below what was measured; the measured number lies above the stated range.
By their numbers in this assay, from the lowest: compounds 3, 2, 1 and 4 (each within the scatter of the next, the first and the last beyond it).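

Among the compounds shown here, at the aryl group on a carbonyl carbon whose other neighbour is an amide-type nitrogen, 3,5-dimethoxyphenyl gives the first steps in this set that lie beyond the scatter in this assay (a 2.3-fold higher number from compound 2 to compound 4 (0.36 log units; beyond the scatter); a 2.5-fold higher number from compound 3 to compound 4 (0.39 log units; beyond the scatter)), both modest and both towards a weaker inhibitor. The three earlier compounds could not separate one aryl group from another, whereas these steps show that the read-out does respond to the group at this position, though only by a small margin. The separation is incomplete, as the remaining step stays within the scatter (a 1.4-fold higher number from compound 1 to compound 4 (0.14 log units; within the scatter)), leaving the 2-fluorophenyl compound 1 and the 3,5-dimethoxyphenyl compound 4 unresolved; nothing available here accounts for the shift.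

The compounds shown leave open whether the shift belongs to having two methoxy groups on the ring or to this particular arrangement of them. They also leave open whether any aryl group at this position can move the number towards a stronger inhibitor, for example a phenyl carrying a dimethylamino group or a carboxylic acid.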